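Epimer of compound 1 in kinetic solubility

The source may report more compounds than this note shows. Statements on the series, on what has been measured and on what is new or still open speak of the compounds shown alone.

Compound 1 `CC(C)[C@@H](C[C@H]1SC(=O)NC1=O)c1ccc(-c2ccc3cccc(F)c3c2)[nH]c1=O` gives 23900 nM in a physicochemical assay for solubility, in phosphate buffer, measured as kinetic solubility (on this read-out lower numbers stand for lower solubility and higher numbers for higher solubility), the highest number of the three, though compound 2 `CC(C)C(c1ccc(-c2ccc3cccc(F)c3c2)[nH]c1=O)C1C(=O)NC(=O)N1C` gives 17900 nM and lies within the scatter of it; compound 3 `CC(C)C(/C=C1\NC(=O)NC1=O)c1ccc(-c2ccc3cccc(F)c3c2)[nH]c1=O` gives 10700 nM, beyond the scatter. Among the measured compounds shown here, the only single-place step measured, a 1.7-fold lower number from compound 2 to compound 3 (0.22 log units; within the scatter), exchanges one five-membered non-aromatic ring for another and moves little. Compound 4 `CC(C)[C@H](C[C@H]1SC(=O)NC1=O)c1ccc(-c2ccc3cccc(F)c3c2)[nH]c1=O` differs from compound 1 only in configuration: the two compounds have the same atoms and bonds and differ only in configuration as drawn: 1 of 2 stereo elements differ; a stereocentre at a saturated chain carbon is drawn R in compound 1 and S in compound 4. For the measured compounds named here, no measured step concerns a change of configuration alone, and the one step that exists stays within the scatter, so no move beyond the scatter is expected. The expected step, a 1.0-fold lower number from compound 1 to compound 4 (0.02 log units; within the scatter), is none beyond the scatter. Compound 4 is estimated to give 23000 nM, with a range from 11000 nM to 48000 nM.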

Compound 4, solubility: 31200 nM
The estimate for compound 4 lay 1.4-fold (0.13 log units) below the measured number, within the range that was stated.
By their numbers in this assay, from the lowest: compounds 3, 2, 1 and 4 (each within the scatter of the next, the first and the last beyond it).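

In this assay, the stereocentre at a saturated chain carbon, drawn R in compound 1 and S in compound 4, gives a 1.3-fold higher number from compound 1 to compound 4 (0.12 log units; within the scatter). Among the compounds shown here, this is the only step of configuration alone, and at this position the assay does not separate the two drawings. Nothing else differs within this pair: the fact that compounds 1 and 4 differ only in the configuration as drawn

The compounds shown leave open whether the second stereo element, shared by compound 1 and compound 4, matters in the same assay. They also leave open how a carboxylic acid or an amine in place of the five-membered non-aromatic ring would read.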